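The source may report more compounds than this note shows. Statements on the series, on what has been measured and on what is new or still open speak of the compounds shown alone.

Working notes on the series.

Two compounds carry numbers in an assay on isolated protein for inhibition of Alpha glucosidase (Homo sapiens), read by spectrophotometry, with stated times of 5 min and 15 min; on this read-out higher numbers stand for weaker inhibition and lower numbers for stronger inhibition. Compound 1 `CO[C@@H]1OC(=O)C(Cc2ccc(O)c(CC=C(C)C)c2)=C1c1ccc(O)cc1` gives 9980 nM in this assay. Compound 2 `COC(=O)[C@]1(Cc2ccc3c(c2)CCC(C)(C)O3)OC(=O)C(O)=C1c1ccc(O)cc1` gives 47300 nM in this assay. For the measured compounds named here, on these two numbers compound 1 stands lowest, with compound 2 sitting beyond the scatter above it; compound 2 differs from compound 1 in more than one place, so no single step is drawn between them and only the two values themselves are read.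

Compound 3 `CO[C@H]1OC(=O)C(Cc2ccc(O)c(CC=C(C)C)c2)=C1c1ccc(O)cc1` is not yet measured in this assay. Against compound 1 the change is the two compounds have the same atoms and bonds and differ only in configuration as drawn: 1 of 1 stereo elements differ; a stereocentre at a saturated ring carbon is drawn R in compound 1 and S in compound 3: the two compounds have the same atoms and bonds and differ only in configuration as drawn, one stereo element differing, a stereocentre at a saturated ring carbon drawn R in compound 1 and S in compound 3. No pair among the measured compounds shows what such an inversion does in this assay, so the size of the step is not anchored by any shown comparison.

With nothing in the shown numbers to point either way, the step from compound 1 to compound 3 is expected to be small and is estimated as a 1.5-fold higher number from compound 1 to compound 3 (0.18 log units; within the scatter). Compound 3 is expected to give about 15000 nM in this assay, with a range from 4000 nM to 60000 nM.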

Compound 3, half-maximal inhibitory concentration: 8650 nM
Compound 3: the middle estimate sits 1.7-fold (0.24 log units) above what was measured; low and high end bracket the measured number.
By their numbers in this assay, from the lowest: compounds 3 and 1 (each within the scatter of the next); then compound 2.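

The stereocentre at a saturated ring carbon now has a direct comparison in this assay, with a 1.2-fold lower number from compound 1 to compound 3 (0.06 log units; within the scatter) on going from the R to the S drawing. The earlier pair, compounds 1 and 2, differs in more than one place and gave no reading of this position, whereas here the assay does not tell the two configurations apart, at least for this pair. The comparison is clean on one point: the fact that compounds 1 and 3 differ only in the configuration as drawn.

The compounds shown leave open whether the same indifference to configuration holds with another group at this carbon, such as an ethoxy group or an amine, or on the core of compound 2. They also leave open how far the number in this assay depends on the group at this carbon at all, a question that only a pair differing in that group, rather than in its configuration, could answer.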